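The source may report more compounds than this note shows. Statements on the series, on what has been measured and on what is new or still open speak of the compounds shown alone.

Two compounds of a shared core carry two diazeniumdiolate groups on a dinitrobenzene, and were tested in a functional assay on HL-60 cells (Homo sapiens) for antiproliferative activity, read by MTT assay, with a stated time of 72 h; a lower number here means a stronger inhibitor of growth, a higher number a weaker inhibitor of growth. Compound 1 `CCCCOC(=O)N1CCN(/[N+]([O-])=N/Oc2cc(O/N=[N+](\[O-])N(C)C)c([N+](=O)[O-])cc2[N+](=O)[O-])CC1` gives 2700 nM in this assay. Compound 2 `CN(C)/[N+]([O-])=N/Oc1cc(O/N=[N+](\[O-])N2CCCCC2)c([N+](=O)[O-])cc1[N+](=O)[O-]` gives 4900 nM, the higher of the two numbers, though the gap to compound 1 lies within the scatter, so the two cannot be ordered.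

Compound 3 `CCN(CC)/[N+]([O-])=N/Oc1cc(O/N=[N+](\[O-])N(C)C)c([N+](=O)[O-])cc1[N+](=O)[O-]` has not yet been tested. It differs from compound 2 in one place: diethylamino in place of piperidin-1-yl on a double-bonded nitrogen. A ring of six heavy atoms is replaced by an open chain of five, with no change in donors, acceptors or charge.

Going by the values given here, no pair of measured compounds shows the effect of such a swap. The two measured values differ only within the scatter, so the expected step from compound 2 to compound 3 is a 1.2-fold lower number from compound 2 to compound 3 (0.09 log units; within the scatter), in no direction beyond the scatter. Compound 3 is therefore estimated at 4000 nM, between 1500 nM and 11000 nM.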

Compound 3, concentration for total growth inhibition: 2300 nM
The estimate for compound 3 lay 1.7-fold (0.24 log units) above the measured number; low and high end bracket the measured number.
By their numbers in this assay, from the lowest: compounds 3, 1 and 2 (each within the scatter of the next, the first and the last beyond it).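

In this assay, opening the piperidin-1-yl ring into the diethylamino chain on this double-bonded nitrogen gives a 2.1-fold lower number from compound 2 to compound 3 (0.33 log units; beyond the scatter) and so provides the first measured effect of a single change in this set. The step is modest, but it shows that the ring is not needed at this place for growth inhibition and that the open chain gives the lower number in this pair. Nothing available explains this difference.

Groups such as pyrrolidin-1-yl, morpholin-4-yl or the longer dipropylamino chain at this place would show whether the step follows from opening the ring or is particular to diethylamino. One pair also leaves open whether the same swap would give a similar step if another group replaced the dimethylamino shared by compound 2 and compound 3.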